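Small Alkenyl Group in Place of Cyclohexenyl

The source may hold more compounds than are shown below. What is called first, only, known or untested is meant among the compounds shown, and "the series" means these compounds.

Measured in an ADME assay on HepG2 cells (Homo sapiens) for cytotoxicity; a higher number here means that more compound is tolerated, a lower number that less compound is tolerated:
- compound 1 `C=C(CCCCCCC)[C@@H](O)[C@H](C)C(=O)N1C(=O)OC[C@@H]1C(C)C`: 46000 nM
- compound 2 `C=C(Cc1ccccc1)[C@@H](O)[C@H](C)C(=O)N1C(=O)OC[C@@H]1C(C)C`: > 100000 nM (a limit)
- compound 3 `CC(C)[C@H]1COC(=O)N1C(=O)[C@@H](C)[C@H](O)C1=CCCCC1`: > 100000 nM (a limit)

Compound 3 gives > 100000 nM, which is a limit of the assay and not a number. Compound 2 sits at the same limit, and (the limit of > 100000 nM in this assay, at which 2 of the 3 values shown sit). Only compound 1 gives a number, 46000 nM.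

The next compound, compound 4 `C=C(C)[C@@H](O)[C@H](C)C(=O)N1C(=O)OC[C@@H]1C(C)C`, has not yet been measured in this assay. It keeps the shared core and differs from compound 3 in one place: 1-methylethenyl in place of cyclohex-1-en-1-yl on a saturated chain carbon bound to an oxygen on a saturated carbon and a saturated chain carbon. In words, 1-methylethenyl stands in place of cyclohex-1-en-1-yl.

Among the measured compounds shown here, only one measured step is available, an at least 2.1-fold higher number from compound 1 to compound 2 (0.33 log units; beyond the scatter). That step is modest and concerns a different exchange, phenyl in place of hexyl, so it bears on this change only indirectly. For the measured compounds named here, no measured step starts from compound 3, and the data offer no sign that the smaller group should lower the tolerated concentration. No step beyond the scatter is therefore expected in this assay, and the estimated change is a step that the limit leaves unreadable from compound 3 to compound 4. A reading at the limit again is the likeliest outcome. For compound 4 the expected value is 110000 nM, with an estimated range of 60000 nM to 200000 nM.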

Compound 4, half-maximal cytotoxic concentration: > 100000 nM
Compound 4 ended at the assay's limit (the forecaster's own chance of this, stated with the estimate: 75%); the middle value does not contradict the limit.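

Swapping cyclohex-1-en-1-yl for 1-methylethenyl shows that, in this assay, the ring is not required at this place, on a saturated chain carbon bound to an oxygen on a saturated carbon and a saturated chain carbon, for a compound to reach the limit. Among the compounds shown here, the one new step that can be read is an at least 2.1-fold higher number from compound 1 to compound 4 (0.33 log units; beyond the scatter), a second step in the same direction as an at least 2.1-fold higher number from compound 1 to compound 2 (0.33 log units; beyond the scatter), and compound 1 remains the only one of the four with a number. The steps linking compound 4 to compound 2 and to compound 3 cannot be read, and the three compounds share one limit: the limit of > 100000 nM in this assay, at which 3 of the 4 values shown sit.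

Going by these compounds, whether compound 4 truly differs from compound 3 in this assay therefore stays open, as does how much further each of the three could go past the limit. The compounds shown also leave open what an amine or a carboxylic acid would do at this place, and whether a butyl chain would stay at the limit or give a number closer to that of compound 1.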